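Replacing a Carbamate Oxygen Group with an Ethylpyrimidine Ring

The compounds below may be only part of what the source reports. "The series", "measured", "known", "first", "only" and "open" are said of these compounds alone.

Compound 1 `Cc1nc(S(C)(=O)=O)ccc1Oc1ncnc(OC2CCN(C(=O)OC3(C(F)(F)F)COC3)CC2)c1F` gives 342 nM in a functional assay on isolated protein for inhibition of Glucose-dependent insulinotropic receptor (Rattus norvegicus), read by HTRF and cAMP accumulation; on this read-out higher numbers stand for an effect only at larger amounts of compound and lower numbers for an effect already at smaller amounts. Compound 2 `Cc1nc(S(C)(=O)=O)ccc1Oc1ncnc(OC2CCN(C(=O)C(F)(F)F)CC2)c1F` gives 880 nM. Compound 3 `Cc1nc(S(C)(=O)=O)ccc1Oc1ncnc(OC2CCN(C(=O)C(C)(F)F)CC2)c1F` gives 239 nM.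

Among these three numbers compound 1 holds the second highest place; compound 3 sits closest to it, while compound 2 lies furthest away. The next compound, compound 4 `CCc1cnc(C(=O)N2CCC(Oc3ncnc(Oc4ccc(S(C)(=O)=O)nc4C)c3F)CC2)nc1`, has not yet been measured. It differs from compound 1 at one spot only: 5-ethylpyrimidin-2-yl in place of (3-(trifluoromethyl)oxetan-3-yl)oxy on a carbonyl carbon.

Going by the values given here, two measured steps touch the same carbonyl carbon. Going a 2.6-fold higher number from compound 1 to compound 2 (0.41 log units; beyond the scatter) raised the number beyond the scatter, whereas going a 1.4-fold lower number from compound 1 to compound 3 (0.16 log units; within the scatter) stayed within it. So swapping the group on this carbonyl carbon has so far moved the number only modestly, in either direction. The 5-ethylpyrimidin-2-yl group is unlike either of those groups, so the comparison is loose, and a step within or just beyond the scatter is expected, with no clear direction. For compound 4 the expected outcome is 280 nM, between 90 nM and 900 nM, which would mean an expected step of a 1.2-fold lower number from compound 1 to compound 4 (0.09 log units; within the scatter).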

Compound 4, half-maximal effective concentration: 40.8 nM
The estimate for compound 4 lay 6.9-fold (0.84 log units) above the measured number; the measured number lies below the stated range.
By their numbers in this assay, from the lowest: compound 4; then compounds 3 and 1 (each within the scatter of the next); then compound 2.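

Until now, changing the group on this carbonyl carbon had shifted the number only modestly, but in this assay a six-membered aromatic ring in this place, the 5-ethylpyrimidin-2-yl group, produces a clearly bigger shift: an 8.4-fold lower number from compound 1 to compound 4 (0.92 log units; beyond the scatter), and a 5.9-fold lower number from compound 3 to compound 4 (0.77 log units; beyond the scatter). The widest gap is to the trifluoromethyl amide, a 22-fold lower number from compound 2 to compound 4 (1.33 log units; beyond the scatter), so this carbonyl carbon accepts an aromatic ring and compound 4 has the lowest number of the four. No measurement shown here explains why this ring lowers the number so much.

The compounds shown leave open how much of the shift belongs to the ring and how much to its ethyl chain, which a plain pyrimidin-2-yl or phenyl group on this carbonyl carbon would help to separate. Going by these compounds, whether a longer chain such as propyl would lower the number further also remains open.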